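A few compounds are considered here, and "the series" means these few. Any claim that something is new, unique, unknown or untested is made for them only; others in the source may bear on it.

Working notes on the series in an assay on a protein complex for inhibition of CDK8/Cyclin C (Homo sapiens), with a stated time of 1 h, tested at 10 uM; a higher number here means more inhibition at the concentration tested (going by the name of the read-out), a lower number less inhibition.

Compound 1, `O=C(O)/C=C/c1ccncc1-c1ccc2cc[nH]c2c1`, gives 103% in this assay, the highest of the three numbers recorded. Compound 2, `CCOC(=O)/C=C/c1ccncc1-c1ccc2c(ccn2C)c1`, gives 100%, within the scatter of compound 1. Compound 3, `O=C(O)CCNC(=O)/C=C/c1ccncc1-c1ccc2ccccc2c1`, gives 91%, beyond the scatter below compound 1.

The step taken here leads from compound 1 to compound 4, `CCOC(=O)/C=C/c1ccncc1-c1ccc2cc[nH]c2c1`. The change is ethyl in place of hydrogen on an oxygen next to a carbonyl group. Within the data shown here, no step between measured compounds of this kind is available, so the expectation rests on the values shown: compound 2 carries the ethoxycarbonyl and gives 100%, close to compound 1.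

The step from compound 1 to compound 4 is therefore expected to be a number 4 percentage points lower from compound 1 to compound 4 (within the scatter), no movement beyond the scatter. Compound 4 is estimated at 99% in this assay, in the range 88% to 106%.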

Compound 4, a percentage reported as inhibition, at one concentration (the size of the read-out at that concentration, not a potency): 104%
The estimate for compound 4 lay 5 percentage points below the measured number; low and high end bracket the measured number.
By their numbers in this assay, from the lowest: compounds 3, 2, 1 and 4 (each within the scatter of the next, the first and the last beyond it).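

In this assay, the change from carboxy to ethoxycarbonyl on the shared core reads as a number 1 percentage points higher from compound 1 to compound 4 (within the scatter). Among these compounds, this is the first direct comparison at this position, and at this single concentration it does not separate the free carboxylic acid from its ethyl ester. No measurement at hand accounts for the two reading alike.

Going by these compounds, a longer chain on this oxygen, such as butyl, remains open, as does replacing the ester with an amine. Any difference in potency between compound 1 and compound 4 also remains open.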